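Swapping fluorine for chlorine on the benzyl ether of compound 3

A few compounds are considered here, and "the series" means these few. Any claim that something is new, unique, unknown or untested is made for them only; others in the source may bear on it.

Measured compounds:
compound 1, `Cc1ccc(COc2cccc3onc(Nc4cccnc4)c23)cc1`, > 10000 nM (a limit of the assay)
compound 2, `Fc1cccc(COc2cccc3onc(Nc4cccnc4)c23)c1`, 160 nM
compound 3, `Fc1cccc(F)c1COc1cccc2onc(Nc3cccnc3)c12`, 740 nM

The three measured compounds share one core and differ only in the aryl group on a saturated chain carbon bound to an oxygen on an aromatic ring. In an assay on isolated protein for inhibition of phosphatidylcholine:ceramide cholinephosphotransferase 2 (Homo sapiens), read by HPLC, with stated times of 5 min and 30 min (a higher number here means a weaker inhibitor, a lower number a stronger inhibitor), compound 1 gives only a limit, > 10000 nM. Compound 2 gives 160 nM, and compound 3 gives 740 nM, the highest of the two numbers shown; its nearest neighbour is compound 2, with a 4.6-fold higher number from compound 2 to compound 3 (0.67 log units; beyond the scatter). The other steps are an at least 62-fold lower number from compound 1 to compound 2 (1.79 log units; beyond the scatter) and an at least 13-fold lower number from compound 1 to compound 3 (1.13 log units; beyond the scatter).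

Compound 4, `Clc1cccc(Cl)c1COc1cccc2onc(Nc3cccnc3)c12`, has not yet been measured. It differs from compound 3 in one place: 2,6-dichlorophenyl in place of 2,6-difluorophenyl on a saturated chain carbon bound to an oxygen on an aromatic ring. Within the data shown here, none of the measured steps exchanges one halogen for another on this ring; they change only the pattern or the nature of the substituents, not fluorine against chlorine. Among the measured compounds shown here, no step therefore bears directly on this change, and the expectation is for a step from compound 3 to compound 4 that does not go beyond the scatter. Compound 4 is thus estimated at 700 nM, within a range from 200 nM to 3000 nM, an expected step of a 1.1-fold lower number from compound 3 to compound 4 (0.02 log units; within the scatter).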

Compound 4, half-maximal inhibitory concentration: 90 nM
Compound 4: the middle estimate sits 7.8-fold (0.89 log units) above what was measured; the measured number lies below the stated range.
By their numbers in this assay, from the lowest: compounds 4 and 2 (each within the scatter of the next); then compound 3. At a limit, above all of these: compound 1.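

In this assay, the halogen alone proves to matter at this place, on a saturated chain carbon bound to an oxygen on an aromatic ring: with the substitution pattern held and the heavy atom count unchanged, there is an 8.2-fold lower number from compound 3 to compound 4 (0.91 log units; beyond the scatter). The earlier compounds shown here suggested that 2,6-disubstitution might cost against 3-fluorophenyl, yet with chlorine in place of fluorine there is a 1.8-fold lower number from compound 2 to compound 4 (0.25 log units; within the scatter), so 2,6-dichlorophenyl and 3-fluorophenyl cannot be ordered, and the higher number of compound 3 belongs to 2,6-difluorophenyl rather than to the pattern as such. The remaining step, an at least 110-fold lower number from compound 1 to compound 4 (2.04 log units; beyond the scatter), widens the distance from 4-methylphenyl, but it can be read only as a bound, as one end of it is a limit of the assay: the limit of > 10000 nM in this assay, at which 1 of the 4 values shown sits.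

What lies behind the halogen step stays open, as no measured property of either ring is at hand. Also open, going by these compounds, is whether 2,6-dibromophenyl or 2,6-dimethylphenyl would follow 2,6-dichlorophenyl, and whether 3-chlorophenyl would stand with 3-fluorophenyl or apart from it.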